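From piperidin-4-yl to pyrimidin-2-yl on an aromatic nitrogen

The source may report more compounds than this note shows. Statements on the series, on what has been measured and on what is new or still open speak of the compounds shown alone.

- Compound 1 (`CN1C(=S)[C@@H](NC(=O)c2n[nH]c(Cc3ccccc3)n2)COc2ccccc21`): > 50000 nM (a limit)
- Compound 2 (`CN1C(=S)[C@@H](NC(=O)c2nc(Cc3ccccc3)n(C3CCNCC3)n2)COc2ccccc21`): > 100000 nM (a limit)

In a toxicity assay on HT-29 cells (Homo sapiens) for cytotoxicity (on this read-out higher numbers stand for lower toxicity in this test and lower numbers for higher toxicity in this test), compound 2 reads > 100000 nM as its result, and that is a limit of the assay, not a number. Compound 1 reads > 50000 nM as its result, which is also a limit. So compound 2 has no exact place on the scale, and neither does the only other compound measured.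

Compound 3 (`CN1C(=S)[C@@H](NC(=O)c2nc(Cc3ccccc3)n(-c3ncccn3)n2)COc2ccccc21`) carries pyrimidin-2-yl in place of piperidin-4-yl on an aromatic nitrogen, so a non-aromatic ring gives way to an aromatic one: pyrimidin-2-yl in place of piperidin-4-yl on an aromatic nitrogen is the full count.

For the measured compounds named here, only one measured step bears on this, and it concerns the same aromatic nitrogen: a step that the two limits leave unreadable from compound 1 to compound 2 has no readable size. It therefore offers no measured size to carry over, and no step beyond the scatter is expected in this assay, in either direction. The estimated step is an at least 1.4-fold lower number from compound 2 to compound 3 (0.15 log units; that floor lies within the scatter) and it is only an expectation. Compound 3 is expected at 70000 nM with 25000 nM to 150000 nM as its estimated range.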

Compound 3, half-maximal cytotoxic concentration: > 100000 nM
Compound 3: no number, only a limit; the forecaster's own chance of this, stated with the estimate: 75%; middle value at least 1.4-fold (0.15 log units) from the limit.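

In this assay compound 3 gives > 100000 nM, a limit of the assay and not a number. For the compounds shown here, the results for compound 1 and compound 2 are limits too, and no step among compound 1, compound 2 and compound 3 can be read. As far as these compounds go, what stays open is whether, and at what concentration, any of these three compounds becomes toxic to these cells.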